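The source may report more compounds than this note shows. Statements on the series, on what has been measured and on what is new or still open speak of the compounds shown alone.

For the measured compounds named here, in a functional assay on M14 cells (Homo sapiens) for cytotoxicity, read by sulforhodamine B assay, with a stated time of 24 h (a lower number here means a stronger inhibitor of growth, a higher number a weaker inhibitor of growth), compound 2 `O=C(/C=C/c1cc2ccccc2[nH]c1=O)c1ccc(O)cc1` gives 6570 nM, the lowest of the two numbers known. Compound 1 `COc1ccc(C(=O)/C=C/c2cc3ccccc3[nH]c2=O)cc1` gives 22500 nM in this assay, and the step of a 3.4-fold lower number from compound 1 to compound 2 (0.53 log units; beyond the scatter) is a change of hydrogen in place of methyl on an oxygen on an aromatic ring. Compound 3 `O=C(/C=C/c1cc2ccccc2[nH]c1=O)c1ccc(Cl)cc1` carries chloro in place of hydroxy on an aromatic carbon. Going by the values given here, no measured step covers this exact change; the only related one, the step of a 3.4-fold lower number from compound 1 to compound 2 (0.53 log units; beyond the scatter), shows that losing the free hydroxy gave a higher number. Compound 3 is therefore expected to show a step of a 2.3-fold higher number from compound 2 to compound 3 (0.36 log units; beyond the scatter), toward a higher number, with an estimate of 15000 nM and a range of 5000 nM to 40000 nM.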

Compound 3, concentration for total growth inhibition: 39700 nM
Beside the measured number, compound 3's estimate is 2.6-fold (0.42 log units) below it, within the range that was stated.
By their numbers in this assay, from the lowest: compound 2; then compounds 1 and 3 (each within the scatter of the next).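

In this assay, a second replacement of the hydroxy now also gives a higher number, with a 6.0-fold higher number from compound 2 to compound 3 (0.78 log units; beyond the scatter) as the step. Chloro and methoxy cannot be told apart at this place, as a 1.8-fold higher number from compound 1 to compound 3 (0.25 log units; within the scatter) shows, so among these three compounds only compound 2, with its free hydroxy, stands apart. Nothing measured here explains why the hydroxy goes with the lower number. As far as these compounds go, whether an amine or a carboxylic acid at this place would give a number as low as that of compound 2 remains open.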